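This account rests on a few compounds, and the source may have more. Where it says the series, first, only, none or still open, it means among the compounds named here.

Three compounds have so far been run in a functional assay on the whole organism for antagonist activity, with Mus musculus as the target; on this read-out lower numbers stand for an effect already at smaller amounts and higher numbers for an effect only at larger amounts of compound. Compound 1, `CC(=O)N(C)C(C)C#CCn1ccnc1`, and compound 2, `CC(=O)N(C)CC#CCn1ccnc1`, are built on one shared core, while compound 3, `CCOC(=O)N(C)CC#CCN1CCCC1`, rests on a different one; how the two cores differ is not broken down here. Compound 4, `CCOC(=O)N(C)C(C)C#CCN1CCCC1`, belongs with compound 3 and has not yet been measured.

In this assay compound 2 reaches only a limit of the assay, > 100 mg/kg, and not a number. In this assay compound 1 likewise gives only a limit, > 100 mg/kg. In this assay compound 3 too stops at a limit, > 100 mg/kg. All three values therefore sit at the limit of > 100 mg/kg in this assay, at which 3 of the 3 values shown sit.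

The change from compound 2 to compound 1 is methyl in place of hydrogen on a saturated chain carbon bound to an amide-type nitrogen and a triple-bonded carbon, and the step it made, a step that the two limits leave unreadable from compound 2 to compound 1, cannot be read, since both ends are limits. The change from compound 3 to compound 4 is methyl in place of hydrogen on a saturated chain carbon bound to an amide-type nitrogen and a triple-bonded carbon, the same change at the same kind of place, this time on the core of compound 3.

For compound 4 in this assay the step is expected to be a step that the limit leaves unreadable from compound 3 to compound 4. This expectation rests on the limit of > 100 mg/kg in this assay, at which 3 of the 3 values shown sit, and on the step that the two limits leave unreadable from compound 2 to compound 1, which gave no sign of a readable change from the same replacement. Compound 4 is thus estimated in this assay at 150 mg/kg, with a range from 50 mg/kg to 500 mg/kg, and the assay is expected most likely to report only a limit again.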

Compound 4, dose for half-maximal effect: > 100 mg/kg
Compound 4: only a limit was reported; the forecaster's own chance of this, stated with the estimate: 85%; the middle value does not contradict the limit.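

In this assay compound 4, like compound 3, gives only a limit and not a number, so no step can be read between compound 3 and compound 4. The picture across the series stays the same: the limit of > 100 mg/kg in this assay, at which 4 of the 4 values shown sit. The compounds shown leave open whether methyl in place of hydrogen at this place alters the dose on either core, and what dose any of the four compounds would need for half-maximal effect.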